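Configuration Changes in a Cytotoxicity Assay Read at Its Limit

The source may report more compounds than this note shows. Statements on the series, on what has been measured and on what is new or still open speak of the compounds shown alone.

Compound 1 `O=C(/C=C\c1ccc(O)cc1)O[C@H]1[C@H](O[C@@H]2CCCC[C@H]2O)O[C@H](CO)[C@@H](O)[C@@H]1O` was tested in a functional assay on SK-OV-3 cells (Homo sapiens) for cytotoxicity, read by sulforhodamine B assay; on this read-out higher numbers stand for weaker inhibition and lower numbers for stronger inhibition. In this assay compound 1 gives > 10000 nM, which is a limit of the assay rather than a number. Compound 2 `O=C(/C=C/c1ccc(O)cc1)O[C@H]1[C@H](O[C@H]2CCCC[C@@H]2O)O[C@H](CO)[C@@H](O)[C@@H]1O` was tested in the same way. In this assay compound 2 gives > 10000 nM, again a limit. The step from compound 1 to compound 2 is a step that the two limits leave unreadable from compound 1 to compound 2; what connects the two is the fact that compounds 1 and 2 differ only in the configuration as drawn, and both values are set by the limit of > 10000 nM in this assay, at which 2 of the 2 values shown sit.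

Compound 3 `O=C(/C=C/c1ccc(O)cc1)O[C@H]1[C@H](O[C@H]2CCCC[C@H]2O)O[C@H](CO)[C@@H](O)[C@@H]1O` is not yet measured. Its difference from compound 1 is the two compounds have the same atoms and bonds and differ only in configuration as drawn: 2 of 8 stereo elements differ; a stereocentre at a saturated ring carbon is drawn R in compound 1 and S in compound 3; a double bond is drawn Z in compound 1 and E in compound 3. Compound 3 therefore shares the E double bond and one of the altered ring stereocentres with compound 2, while keeping the other ring stereocentre as drawn in compound 1.

For the measured compounds named here, the only measured step that bears on this change is the one from compound 1 to compound 2, and its size cannot be read because the limit of > 10000 nM in this assay, at which 2 of the 2 values shown sit, covers both ends of it. No step beyond the scatter can be expected from the data shown, so compound 3 is expected to stay at the limit, an expected step that the limit leaves unreadable from compound 1 to compound 3. Compound 3 is expected to give 15000 nM, within a range from 5000 nM to 50000 nM.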

Compound 3, half-maximal inhibitory concentration: > 10000 nM
Compound 3: only a limit was reported; the forecaster's own chance of this, stated with the estimate: 85%; the middle value does not contradict the limit.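

In this assay compound 3 gives > 10000 nM, which is a limit of the assay and not a number. No step among compound 1, compound 2 and compound 3 can be read, as all three sit at the same limit: the limit of > 10000 nM in this assay, at which 3 of the 3 values shown sit.

The compounds shown leave open whether the drawn configuration of the double bond or the ring stereocentres changes cytotoxicity at all.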